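This account rests on a few compounds, and the source may have more. Where it says the series, first, only, none or still open, it means among the compounds named here.

Of the compounds shown here, three sharing one core have been measured in a functional assay on Hs 683 cells (Homo sapiens) for inhibition, read by MTT assay, with a stated time of 72 h; on this read-out higher numbers stand for weaker inhibition of growth and lower numbers for stronger inhibition of growth. Compound 1, `CC(C)=CCC/C(C)=C/CC/C(C)=C/C(=O)NC(=N)NC(=O)C=C(C)C`, gives 8300 nM. Compound 2, `CC(C)=CCC/C(C)=C/C(=O)NC(=N)NC(=O)C=C(C)C`, gives 31500 nM. Compound 3, `CC(C)=CCC/C(C)=C/CC/C(C)=C/C(=O)NC(=N)NC(=O)/C=C(\C)CC/C=C(\C)CCC=C(C)C`, gives 6800 nM. Among these three numbers compound 3 has the lowest, though its gap to compound 1 lies within the scatter of this assay; only its gap to compound 2 is beyond it.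

Compound 4, `CC(C)=CCC/C(C)=C/CC/C(C)=C/C(=O)NC(=N)NC(=O)/C=C(\C)CCC=C(C)C`, has not been measured yet. Its structure differs from compound 3 in one spot: hydrogen in place of 3-methylbut-2-en-1-yl on a saturated chain carbon bound to a double-bonded chain carbon.

Two measured steps speak to this. The step of a 3.8-fold higher number from compound 1 to compound 2 (0.58 log units; beyond the scatter) removed the same kind of group from the other end of the core and gave a modest weakening. The step of a 1.2-fold lower number from compound 1 to compound 3 (0.09 log units; within the scatter) added the longer chain at the very place now being shortened and stayed within the scatter. Since compound 4 sits between compound 3 and compound 1 in chain length, and the whole span between those two is within the scatter, the step to compound 4 is expected to be small, most likely a slight rise.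

The expected outcome is a 1.1-fold higher number from compound 3 to compound 4 (0.04 log units; within the scatter), placing compound 4 at an estimated 7500 nM, with a likely range from 4000 nM to 14000 nM.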

Compound 4, concentration for 50% growth inhibition: 37400 nM
Beside the measured number, compound 4's estimate is 5.0-fold (0.70 log units) below it, and the stated range ends below it.
By their numbers in this assay, from the lowest: compounds 3 and 1 (each within the scatter of the next); then compounds 2 and 4 (each within the scatter of the next).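

In this assay, chain length at this place does not act in steady steps: putting 3-methylbut-2-en-1-yl in place of hydrogen on the core of compound 1 weakens growth inhibition (a 4.5-fold higher number from compound 1 to compound 4 (0.65 log units; beyond the scatter)), while the longer 3,7-dimethylocta-2,6-dien-1-yl at the same place stays within the scatter (a 1.2-fold lower number from compound 1 to compound 3 (0.09 log units; within the scatter)), and cutting that longer group back brings the loss (a 5.5-fold higher number from compound 3 to compound 4 (0.74 log units; beyond the scatter)). Removing 3-methylbut-2-en-1-yl from a saturated chain carbon bound to a double-bonded chain carbon thus costs a similar amount on both cores: the same change on two cores in this assay, a 3.8-fold higher number (0.58 log units; beyond the scatter) from compound 1 to compound 2 and a 5.5-fold higher number (0.74 log units; beyond the scatter) from compound 3 to compound 4, 1.4-fold (0.16 log units) apart, within the scatter of two such steps. Adding 3,7-dimethylocta-2,6-dien-1-yl likewise stays within the scatter on a second core (a 1.2-fold higher number from compound 2 to compound 4 (0.07 log units; within the scatter)), so that change also repeats: the same change on two cores in this assay, a 1.2-fold lower number (0.09 log units; within the scatter) from compound 1 to compound 3 and a 1.2-fold higher number (0.07 log units; within the scatter) from compound 2 to compound 4, 1.4-fold (0.16 log units) apart, within the scatter of two such steps.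

The compounds shown leave open why the intermediate chain on this side does worse than both the shorter and the longer one, since three chain lengths at this place give no reason for it. They also leave open how this place would respond to a fully saturated chain of the same length, or to a chain ending in a carboxylic acid or an amine.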